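This account rests on a few compounds, and the source may have more. Where it says the series, first, only, none or still open, it means among the compounds named here.

The series rests on one shared core carrying a substituted phenyl group. Compound 1 `Cc1nn(-c2ccccc2I)c2c1C(c1ccc(Oc3ccccc3)cc1)SC(C)C(=O)N2` and compound 3 `Cc1nn(-c2ccccc2Br)c2c1C(c1ccc(Oc3ccccc3)cc1)SC(C)C(=O)N2` differ only in a halogen: in an assay on isolated protein for agonist activity at Bile acid receptor (Homo sapiens), read by AlphaScreen, with a stated time of 30 min (on this read-out higher numbers stand for an effect only at larger amounts of compound and lower numbers for an effect already at smaller amounts), compound 1 gives 1300 nM, while compound 3 gives 1800 nM, and the change of bromo in place of iodo on an aromatic carbon amounts to a 1.4-fold higher number from compound 1 to compound 3 (0.14 log units; within the scatter). Compound 2 `COC(=O)c1cccc(-c2ccc([C@H]3S[C@@H](C)C(=O)Nc4c3c(C)nn4-c3ccccc3C)cc2)c1` carries a 3-(methoxycarbonyl)phenyl on the aromatic ring instead of the phenoxy group; in this assay compound 2 is reported as "not active" (no number reported), so no single number places it against compound 1 or compound 3. Compound 4 `COC(=O)c1ccc(-c2ccc([C@H]3S[C@@H](C)C(=O)Nc4c3c(C)nn4-c3ccccc3C)cc2)cc1` has not been measured. Among the compounds with values here, it differs from compound 2 in one place: 4-(methoxycarbonyl)phenyl in place of 3-(methoxycarbonyl)phenyl on an aromatic carbon The one measured step, the halogen exchange between compound 1 and compound 3, touches a different part of the core and does not bear on a move of the methoxycarbonyl group around its ring, so no measured step tells the size or direction of this change in this assay. Since compound 2 showed no measurable response, compound 4 is expected to remain weak in this assay, with an estimated value near 6000 nM and a likely range from 1000 nM to 40000 nM, and a real chance that again only a limit is reported.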

Compound 4, half-maximal effective concentration: "not active" (no number reported)
The entry for compound 4 holds no number; the estimate stays without a comparison.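

Within the data shown here, compound 4, like compound 2, is reported in this assay as active at no stated amount and carries no number, so no step between them can be read. Nothing shown gives a reason for this result. The compounds shown leave open whether moving the methoxycarbonyl group around its ring changes the response at all.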